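Alkoxy-to-hydroxy step on the shared core

A few compounds are considered here, and "the series" means these few. Any claim that something is new, unique, unknown or untested is made for them only; others in the source may bear on it.

Among the compounds with values here, compound 2 `CCCOc1ccc2c(c1)SCC(=O)N2` holds the lowest of the two numbers so far: in an assay on isolated protein for inhibition of Amine oxidase [flavin-containing] B (Homo sapiens), read by fluorescence and spectrophotometry, with a stated time of 20 min (a lower number here means a stronger inhibitor, a higher number a weaker inhibitor), compound 2 gives 2870 nM, whereas compound 1 `COc1ccc2c(c1)SCC(=O)N2` gives 42600 nM. Within the data shown here, the one measured step, a 15-fold lower number from compound 1 to compound 2 (1.17 log units; beyond the scatter), came with ethyl in place of hydrogen on a saturated chain carbon bound to an oxygen on an aromatic ring. Compound 3 `O=C1CSc2cc(O)ccc2N1` is not yet measured; relative to compound 2 the change is hydrogen in place of propyl on an oxygen on an aromatic ring, that is propoxy to hydroxy. Among the measured compounds shown here, the single measured step bears directly on this: lengthening the chain on that oxygen lowered the number strongly, so removing the chain altogether is expected to raise it, by a step at least as large and in the direction of a weaker inhibitor. For compound 3 in this assay the expected step is a 21-fold higher number from compound 2 to compound 3 (1.32 log units; beyond the scatter). Compound 3 is therefore estimated at 60000 nM, within a range of 15000 nM to 250000 nM.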

Compound 3, half-maximal inhibitory concentration: 20000 nM
For compound 3 the middle estimate is 3.0-fold (0.48 log units) above the measured one; the range from low to high includes it.
By their numbers in this assay, from the lowest: compound 2; then compound 3; then compound 1.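

In this assay, the oxygen on the aromatic ring now carries three different substituents, and the numbers do not follow chain length alone. Propoxy to hydroxy raises the number (a 7.0-fold higher number from compound 2 to compound 3 (0.84 log units; beyond the scatter)), so the propyl chain is worth more than a bare hydroxy on this core. Replacing methyl with hydrogen on the same oxygen, however, lowers the number (a 2.1-fold lower number from compound 1 to compound 3 (0.33 log units; beyond the scatter)), which leaves compound 1, not compound 3, with the highest number of the three and makes compound 1 the exception to any trend of shorter chain, higher number.

From the compounds shown here alone, whether a longer chain such as butoxy or a benzyl group on this oxygen lowers the number further than propyl remains open. No supporting measurement bears on why methoxy falls out of order.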